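Hydroxy in Place of Hydrogen on the Styryl Phenyl

The source may hold more compounds than are shown below. What is called first, only, known or untested is meant among the compounds shown, and "the series" means these compounds.

Compound 2 `COc1ccc(C(=O)/C=C/c2ccccc2)c2c1C=CC(C)(C)O2` carries the shared core with a plain phenyl on the enone. In a functional assay on HCT-116 cells (Homo sapiens) for antiproliferative activity, read by MTT assay, with a stated time of 24 h (on this read-out lower numbers stand for stronger inhibition and higher numbers for weaker inhibition), compound 2 gives only a limit, > 10000 nM, so its standing rests on the limit of > 10000 nM in this assay, at which 1 of the 3 values shown sits, rather than on a number. Compound 1 `COc1ccc(C(=O)/C=C/c2ccc(N(C)C)cc2)c2c1C=CC(C)(C)O2` gives 1920 nM in this assay, and compound 3 `COc1ccc(C(=O)/C=C/c2cccc(C(F)(F)F)c2)c2c1C=CC(C)(C)O2` gives 9710 nM. The step of an at least 5.2-fold higher number from compound 1 to compound 2 (0.71 log units; beyond the scatter) is beyond the scatter, whereas an at least 1.0-fold lower number from compound 2 to compound 3 (0.01 log units; that floor lies within the scatter) cannot be read as a change.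

Compound 4 `COc1ccc(C(=O)/C=C/c2ccc(O)cc2)c2c1C=CC(C)(C)O2` is not yet measured. Against compound 2 the change is hydroxy in place of hydrogen on an aromatic carbon. Among the compounds with values here, the one measured step at the same place is an at least 5.2-fold higher number from compound 1 to compound 2 (0.71 log units; beyond the scatter), which sets a dimethylamino-bearing phenyl against a plain one; hydroxy is a different group, so that step is a rough guide only. Substitution on that ring elsewhere, as in compound 3, gave no readable step. The expectation for compound 4 is therefore a lowering, an at least 2.5-fold lower number from compound 2 to compound 4 (0.39 log units; beyond the scatter), likely smaller than the step seen with dimethylamino. Compound 4 is estimated at 4000 nM in this assay, between 1500 nM and 12000 nM, with a real chance that only a limit is reported.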

Compound 4, half-maximal inhibitory concentration: > 10000 nM
Compound 4 ended at the assay's limit (the forecaster's own chance of this, stated with the estimate: 35%); middle value at least 2.5-fold (0.39 log units) away from the limit.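

In this assay compound 4 gives > 10000 nM, which is a limit and not a number. The step between compound 2 and compound 4 cannot be read, because both compounds stand at a limit: the limit of > 10000 nM in this assay, at which 2 of the 4 values shown sit. Hydroxy in place of dimethylamino, on the aromatic carbon para to a large group, gives an at least 5.2-fold higher number from compound 1 to compound 4 (0.71 log units; beyond the scatter), so a substituent at this place does not by itself bring the number down, and of the groups shown there only dimethylamino, in compound 1, gives a value clear of the limit.

Going by these compounds, it remains open whether that lowering belongs to dimethylamino alone or extends to other groups at this place, such as a primary amine, a morpholine or a methoxy group. Any effect of hydroxy relative to hydrogen also stays hidden behind the limit.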